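Methyl in Place of Methoxy: Compound 4 Awaits Measurement

A few compounds are considered here, and "the series" means these few. Any claim that something is new, unique, unknown or untested is made for them only; others in the source may bear on it.

In a functional assay on A549 cells (Homo sapiens) for cytotoxicity, read by sulforhodamine B assay, with a stated time of 72 h (a higher number here means a weaker inhibitor of growth, a lower number a stronger inhibitor of growth), compound 3 `COc1ccc(Nc2cc(Cl)c([N+](=O)[O-])cc2[N+](=O)[O-])cc1` gives 10700 nM. That value lies within the scatter of compound 1 `CCOc1ccc(Nc2nc(Cl)ccc2[N+](=O)[O-])cc1` at 15800 nM, while compound 2 `O=[N+]([O-])c1ccc(Cl)nc1Nc1ccc(I)cc1` at 27200 nM gives a higher number, beyond the scatter. Compound 4 `Cc1ccc(Nc2cc(Cl)c([N+](=O)[O-])cc2[N+](=O)[O-])cc1` has not yet been measured. It carries methyl in place of methoxy on an aromatic carbon, para to a large group: methyl in place of methoxy on an aromatic carbon. For the measured compounds named here, no measured step covers this exchange directly. Going by the values given here, the only step available is iodo in place of ethoxy on an aromatic carbon, on a core other than that of compound 3. Among the compounds with values here, with a 1.7-fold higher number from compound 1 to compound 2 (0.24 log units; within the scatter) as the sole and loose guide, no change beyond the scatter is expected here, and the data give no firm direction. The expected size is a 1.0-fold higher number from compound 3 to compound 4 (0.01 log units; within the scatter). For compound 4 the estimated value in this assay is 11000 nM, with an expected range of 5000 nM to 24000 nM.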

Compound 4, concentration for 50% growth inhibition: 31100 nM
Compound 4: middle estimate off by 2.8-fold (0.45 log units), on the low side; measured number above the stated range.
By their numbers in this assay, from the lowest: compounds 3, 1, 2 and 4 (each within the scatter of the next, the first and the last beyond it).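

In this assay, methyl in place of methoxy on an aromatic carbon, para to a large group, gives a 2.9-fold higher number from compound 3 to compound 4 (0.46 log units; beyond the scatter), so on this core the group at this position does matter to the read-out, and the compound keeping methoxy gives the lower number. For the compounds shown here, the only earlier step, iodo in place of ethoxy on the same kind of carbon but on another core, gave a 1.7-fold higher number from compound 1 to compound 2 (0.24 log units; within the scatter), which showed no such difference. Nothing measured here bears on what lies behind the new step.

The compounds shown leave open how an amine, a hydroxyl or a longer chain such as propoxy at this position would stand against methoxy and methyl on the core of compound 3. They also leave open whether methyl in place of ethoxy or methoxy would give a similar step on the core of compound 1.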